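A few compounds are considered here, and "the series" means these few. Any claim that something is new, unique, unknown or untested is made for them only; others in the source may bear on it.

Measured compounds in an ADME assay on the whole organism (plasma, Rattus norvegicus, strain Sprague-Dawley) for pharmacokinetics, read by LC-MS, using cassette dosing, at a dose of 0.2 mg/kg by the intravenous route; on this read-out higher numbers stand for higher exposure at the dose given and lower numbers for lower exposure:

- compound 1 `CNCc1cn(S(=O)(=O)c2cc(OC)ccn2)c(-c2cccnc2F)c1F`: 38 ng.h/mL
- compound 2 `CNCc1cn(S(=O)(=O)c2cccc(C)n2)c(-c2cccnc2F)c1F`: 41 ng.h/mL
- compound 3 `CNCc1cn(S(=O)(=O)c2cccc(F)n2)c(-c2cccnc2F)c1F`: "not determined" (no result reported)

Compound 1 gives the lower of the two numbers in hand, with compound 2 nearest; the step of a 1.1-fold higher number from compound 1 to compound 2 (0.03 log units; within the scatter) lies within the scatter, so the two are indistinguishable on this read-out. Compound 3 contributes no number.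

Compound 4 `CNCc1cn(S(=O)(=O)c2cccnc2C)c(-c2cccnc2F)c1F` differs from compound 1 in one place: 2-methylpyridin-3-yl in place of 4-methoxypyridin-2-yl on a sulfonyl sulfur. Among the measured compounds shown here, the only measured step, a 1.1-fold higher number from compound 1 to compound 2 (0.03 log units; within the scatter), swaps one substituted pyridin-2-yl for another on the sulfonyl sulfur and moves nothing beyond the scatter. For the measured compounds named here, compound 4 instead brings in a 2-methylpyridin-3-yl, a change of a different kind, and no measured pair speaks to that directly. Going by the values given here, the one comparison available therefore points to no step beyond the scatter, but with little support, so the range is kept wide.

Compound 4 is expected in this assay at about 40 ng.h/mL, between 15 ng.h/mL and 110 ng.h/mL, which means an estimated step of a 1.1-fold higher number from compound 1 to compound 4 (0.02 log units; within the scatter).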

Compound 4, area under the concentration-time curve: 32 ng.h/mL
Beside the measured number, compound 4's estimate is 1.3-fold (0.10 log units) above it, and the stated range covers the measured number.
By their numbers in this assay, from the lowest: compounds 4, 1 and 2 (each within the scatter of the next).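

In this assay, a 2-methylpyridin-3-yl on the sulfonyl sulfur stays within the scatter of both substituted pyridin-2-yl groups with numbers (a 1.2-fold lower number from compound 1 to compound 4 (0.07 log units; within the scatter); a 1.3-fold lower number from compound 2 to compound 4 (0.11 log units; within the scatter)). Among the compounds shown here, this is the first measured step that replaces a pyridin-2-yl group with a pyridin-3-yl group at this place, and the read-out does not separate the two kinds of group in these compounds. No evidence is available to explain why these numbers stay so close.

Going by these compounds, whether a phenyl group, a carboxylic acid or an aminoalkyl chain on the sulfonyl sulfur would give a step beyond the scatter remains open. Compound 3 has no number, so steps to it cannot be read.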